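This account rests on a few compounds, and the source may have more. Where it says the series, first, only, none or still open, it means among the compounds named here.

Measured so far:
- compound 1 `COc1ccc([N+](=O)[O-])c(-c2nnc(C3=C(Cl)c4ccccc4CCC3)o2)c1OC` gives 7230 nM
- compound 2 `Cc1cc2c(cc1C)C(Cl)=C(c1nnc(-c3ccccc3)o1)CCC2` gives 4120 nM

In a functional assay on PANC-1 cells (Homo sapiens) for antiproliferative activity, read by sulforhodamine B assay, with a stated time of 48 h (on this read-out lower numbers stand for stronger inhibition of growth and higher numbers for weaker inhibition of growth), compound 2 stands at 4120 nM and compound 1 at 7230 nM, within the usual scatter of each other, so the pair gives no ranking. Compound 3 `Cc1cc2c(cc1C)C(Cl)=C(c1nnc(-c3cccc(C(F)(F)F)c3)o1)CCC2` departs from compound 2 in one place, (trifluoromethyl in place of hydrogen on an aromatic carbon), with trifluoromethyl in place of hydrogen on an aromatic carbon, meta to a large group. Among the measured compounds shown here, no measured pair differs in only one place, so the data offer no direct precedent for this change. In this assay, going by these compounds, no step beyond the scatter is expected, and the direction remains open. The estimate corresponds to a 1.2-fold lower number from compound 2 to compound 3 (0.07 log units; within the scatter) as the expected step. For compound 3 the estimated value is 3500 nM, with an expected range from 1300 nM to 9500 nM when it is measured.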

Compound 3, concentration for 50% growth inhibition: 794 nM
For compound 3 the middle estimate is 4.4-fold (0.64 log units) above the measured one; the whole stated range lies above it.
By their numbers in this assay, from the lowest: compound 3; then compounds 2 and 1 (each within the scatter of the next).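

In this assay, trifluoromethyl in place of hydrogen on an aromatic carbon, meta to a large group, gives a 5.2-fold lower number from compound 2 to compound 3 (0.72 log units; beyond the scatter), the only step among these compounds that can be read. It shows that this position on the phenyl-free side of the comparison is not silent: a single change on this six-membered aromatic ring of carbon only is enough to move growth inhibition beyond the scatter, which the earlier pair, differing in more than one place, could not show. Nothing measured here accounts for the size of this step.

Going by these compounds, whether another group in the same place, such as a nitrile or an amine, would move the number in the same way stays open. Also open, on these data alone, is whether the same change would have a similar effect on the core of compound 1.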